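The source may report more compounds than this note shows. Statements on the series, on what has been measured and on what is new or still open speak of the compounds shown alone.

Measured compounds:
compound 1 `CC/C=C/C(=O)Nc1cc2c(N3CCCc4ccccc43)ncnc2cc1OC` — 2870 nM
compound 2 `CC/C=C/C(=O)Nc1cc2c(N3CCCc4ccccc43)ncnc2cc1O[C@@H]1CCOC1` — 14400 nM
compound 3 `O=C(/C=C/CN1CCC(CO)CC1)Nc1cc2c(N3CCc4ccccc43)ncnc2cc1O[C@@H]1CCOC1` — 4690 nM

In a functional assay on MCF7 cells (Homo sapiens) for antiproliferative activity, read by MTT assay, with a stated time of 72 h (a higher number here means a weaker inhibitor, a lower number a stronger inhibitor), compound 1 gives the lowest of the three numbers. Among the compounds with values here, its gap to compound 3 lies within the scatter, while compound 2 sits beyond it; the one single-point step in the set, a 5.0-fold higher number from compound 1 to compound 2 (0.70 log units; beyond the scatter), concerns the ether oxygen on the aromatic ring and not the chain that is changed here.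

Compound 4 `COc1cc2ncnc(N3CCCc4ccccc43)c2cc1NC(=O)/C=C/CN1CCN(C)CC1` differs from compound 1 by 4-methylpiperazin-1-yl in place of methyl on a saturated chain carbon bound to a double-bonded chain carbon. Within the data shown here, no measured pair isolates this change: compound 3 carries a ring amine on the same saturated chain carbon, but it differs from compound 2 in more than one place, so its number and that of compound 2 can only be compared as they stand. Among the measured compounds shown here, with no direct precedent, compound 4 is expected to stay close to compound 1 in this assay, and the step of a 1.8-fold lower number from compound 1 to compound 4 (0.25 log units; within the scatter) is estimated to remain within the scatter, if anything toward a lower number. The estimate for compound 4 is 1600 nM, with a range from 500 nM to 5000 nM.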

Compound 4, half-maximal inhibitory concentration: 8560 nM
For compound 4 the middle estimate is 5.4-fold (0.73 log units) below the measured one; measured number above the stated range.
By their numbers in this assay, from the lowest: compounds 1, 3, 4 and 2 (each within the scatter of the next, the first and the last beyond it).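

In this assay, placing 4-methylpiperazin-1-yl in place of methyl on a saturated chain carbon bound to a double-bonded chain carbon gives a 3.0-fold higher number from compound 1 to compound 4 (0.47 log units; beyond the scatter). Within the data shown here, this is the first single-point reading at this position, and it shows that the chain tolerates the larger ring-bearing group only with a modest loss, not with the unchanged number seen as possible before. No measurement shown here bears on the reason for this rise.

On these data alone, whether the rise belongs to the piperazine ring or to any amine on that carbon stays open, and a dimethylamino group or morpholin-4-yl on the chain of compound 1 would separate the two. It also remains unsettled whether the change behaves alike with oxolan-3-yl on the ring oxygen, since compound 3 differs from compound 2 in more than one place.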